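Ethoxy-linked pyrimidine series: sulfur linker and demethylated pyrimidine

The source may report more compounds than this note shows. Statements on the series, on what has been measured and on what is new or still open speak of the compounds shown alone.

Measured so far:
compound 1 `COCCOc1ncnc(NS(=O)(=O)c2ccc(C(C)(C)C)cc2)c1Oc1cccc(OC)c1` — 92 nM
compound 2 `COc1cccc(Oc2c(NS(=O)(=O)c3ccc(C(C)(C)C)cc3)ncnc2OCCOc2ncc(C)cn2)c1` — 0.86 nM

Both values come from an assay on cells (Endothelial cell) for binding affinity to Endothelin-1 receptor (Sus scrofa); on this read-out lower numbers stand for stronger inhibition and higher numbers for weaker inhibition. Compound 2 holds the lowest number of the two; its nearest neighbour is compound 1, which stands higher by a 110-fold lower number from compound 1 to compound 2 (2.03 log units; beyond the scatter). Among the measured compounds shown here, that single step, the exchange of a methyl on the ether oxygen for a 5-methylpyrimidin-2-yl, is the only measured step, and it is large.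

Compound 3 `COc1cccc(Oc2c(NS(=O)(=O)c3ccc(C(C)(C)C)cc3)ncnc2SCCOc2ncccn2)c1` has not been measured. Relative to compound 2 the change is (2-((pyrimidin-2-yl)oxy)ethyl)sulfanyl in place of 2-((5-methylpyrimidin-2-yl)oxy)ethoxy on an aromatic carbon. Two things move at once: the oxygen linking the chain to the core becomes a sulfur, and the methyl on the pyrimidine is gone. Neither change has a measured precedent here; the step from compound 1 to compound 2 only shows that the pyrimidinyloxyethyl arm itself carries most of the gain, and compound 3 keeps that arm. A step within or slightly beyond the scatter toward a higher number is therefore expected, a 3.5-fold higher number from compound 2 to compound 3 (0.54 log units; beyond the scatter). For compound 3 in this assay the estimate is 3 nM, with a range from 0.7 nM to 15 nM.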

Compound 3, half-maximal inhibitory concentration: 25.8 nM
Compound 3: middle estimate off by 8.6-fold (0.93 log units), on the low side; the whole stated range lies below it.
By their numbers in this assay, from the lowest: compound 2; then compound 3; then compound 1.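

In this assay, the pyrimidinyloxyethyl arm turns out not to hold its gain on its own: the earlier step was a 110-fold lower number from compound 1 to compound 2 (2.03 log units; beyond the scatter) for the ether-linked arm bearing the 5-methyl group, whereas the double change at this position gives a 30-fold higher number from compound 2 to compound 3 (1.48 log units; beyond the scatter) and so gives back most of that gain. Some advantage over the plain 2-methoxyethoxy chain survives, as a 3.6-fold lower number from compound 1 to compound 3 (0.55 log units; beyond the scatter) shows, which places the (2-((pyrimidin-2-yl)oxy)ethyl)sulfanyl group between the two ether-linked chains in this set of three compounds. The number at this position therefore depends on more than the presence of the terminal pyrimidine, though no data here give a reason for the loss.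

The two changes remain unseparated, since neither the ethoxy-linked arm with an unsubstituted pyrimidine nor the sulfanyl-linked arm with the 5-methylpyrimidine is among the compounds shown, so the share of the linking sulfur and that of the lost methyl stay unknown. Also open, going by these compounds, is how an amine nitrogen as the link to the core, or a longer chain before the pyrimidine, would read in this assay.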